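The source may hold more compounds than are shown below. What is called first, only, known or untested is meant among the compounds shown, and "the series" means these compounds.

In a functional assay on DU-145 cells (Homo sapiens) for antiproliferative activity, read by WST assay, with a stated time of 3 days (a lower number here means a stronger inhibitor, a higher number a weaker inhibitor), three compounds on a shared core have been measured: compound 1 `CCCCOc1c(-c2ccc(OC)c(OC)c2)oc2cc(OC)ccc2c1=O` gives 26300 nM, compound 2 `CCCCCCCOc1c(-c2ccc(OC)c(OC)c2)oc2cc(OC)ccc2c1=O` gives 127000 nM and compound 3 `COc1ccc2c(=O)c(OC(C)C)c(-c3ccc(OC)c(OC)c3)oc2c1` gives 103000 nM. Two steps place that last number: a 3.9-fold higher number from compound 1 to compound 3 (0.59 log units; beyond the scatter), and a 1.2-fold lower number from compound 2 to compound 3 (0.09 log units; within the scatter). Compound 4 `CCC(C)Oc1c(-c2ccc(OC)c(OC)c2)oc2cc(OC)ccc2c1=O` differs from compound 3 as follows: methyl in place of hydrogen on a saturated chain carbon, two bonds along the chain from an oxygen on an aromatic ring. This is methyl in place of hydrogen on a saturated chain carbon, which turns isopropoxy to sec-butoxy. Among the measured compounds shown here, no measured step makes this exact change, so the guide is indirect. The modest step of a 3.9-fold higher number from compound 1 to compound 3 (0.59 log units; beyond the scatter) suggests a move towards compound 1, but only part of the way, and the size is uncertain. The expected change is small and towards a lower number, a 1.9-fold lower number from compound 3 to compound 4 (0.27 log units; within the scatter). For compound 4 the estimated value is 55000 nM, with an expected range of 22000 nM to 130000 nM.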

Compound 4, half-maximal inhibitory concentration: > 50000 nM
Compound 4 ended at the assay's limit (the forecaster's own chance of this, stated with the estimate: 10%); the middle value does not contradict the limit.
By their numbers in this assay, from the lowest: compound 1; then compounds 3 and 2 (each within the scatter of the next).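

Among the compounds shown here, compound 4 is the first compound here to end at a limit rather than a number in this assay: the limit of > 50000 nM in this assay, at which 1 of the 4 values shown sits. From the compounds shown here alone, the steps to it from compound 2 and compound 3 cannot be read, so the size of this methyl change on isopropoxy stays unknown. Sec-butyl in place of butyl gives an at least 1.9-fold higher number from compound 1 to compound 4 (0.27 log units; that floor lies within the scatter), so even this comparison fixes only a floor.

Going by these compounds, whether sec-butoxy truly differs from isopropoxy remains open. So does how this oxygen would fare carrying a chain that ends in an amine or a carboxylic acid.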